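The source may hold more compounds than are shown below. What is called first, only, known or untested is meant among the compounds shown, and "the series" means these compounds.

Working notes on the series. Compound 1 `COC(=O)c1nc(-c2ccoc2)n(-c2ccc(F)cc2)n1` has been measured in a functional assay on NPC-TW01 cells (Homo sapiens) for inhibition, read by MTT assay, with a stated time of 72 h (a higher number here means a weaker inhibitor of growth, a lower number a stronger inhibitor of growth), where compound 1 gives 11700 nM. Compound 2 `COC(=O)c1nc(C2CCCCC2)n(-c2ccc(C(F)(F)F)cc2)n1` stands apart: the reading for compound 2 in this assay is > 100000 nM, which is a limit of the assay and not a number, and it sits at the limit of > 100000 nM in this assay, at which 1 of the 2 values shown sits. So for compound 2 only a floor is known, and its true value is not fixed on the numbers shown.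

The step under consideration goes from compound 2 to compound 3 `COC(=O)c1nc(-c2ccoc2)n(-c2ccc(C(F)(F)F)cc2)n1`. The change is furan-3-yl in place of cyclohexyl on an aromatic carbon. Among the compounds with values here, no step between measured compounds covers this exchange, so its size cannot be read off directly. Within the data shown here, what can be said is that the furan-3-yl group is the one carried by compound 1, whose reading in this assay is a number rather than a limit, while compound 2 with cyclohexyl gives only a limit; compound 1 and compound 3 differ elsewhere, so only their two values can be set side by side.

The expectation is therefore that compound 3 comes back into the measurable range, a step of an at least 4.0-fold lower number from compound 2 to compound 3 (0.60 log units; beyond the scatter) in the direction of stronger growth inhibition, clearly beyond the scatter. The estimate for compound 3 in this assay is 25000 nM, with a range from 8000 nM to 90000 nM.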

Compound 3, concentration for 50% growth inhibition: > 100000 nM
Compound 3: no number, only a limit; the forecaster's own chance of this, stated with the estimate: 30%; middle value at least 4.0-fold (0.60 log units) from the limit.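

In this assay compound 3 gives > 100000 nM, which is a limit of the assay and not a number. Trifluoromethyl in place of fluoro on an aromatic carbon gives an at least 8.5-fold higher number from compound 1 to compound 3 (0.93 log units; beyond the scatter), so furan-3-yl on this aromatic carbon does not by itself keep the reading in the measurable range, and among the compounds shown a number appears only where it is paired with fluoro, in compound 1. The exchange of cyclohexyl for furan-3-yl between compound 2 and compound 3 cannot be read, because both compounds stand at the same limit: the limit of > 100000 nM in this assay, at which 2 of the 3 values shown sit.

Open, on these data alone, is whether cyclohexyl paired with fluoro would give a number in this assay, which would allow the exchange of cyclohexyl for furan-3-yl to be sized. Also open, as far as these compounds go, is how chloro or methoxy in place of fluoro, or a carboxylic acid or an amide in place of the methoxycarbonyl group, would read on the core of compound 1.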